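Swapping nitro for bromo on the aryl ring of compound 2

The source may report more compounds than this note shows. Statements on the series, on what has been measured and on what is new or still open speak of the compounds shown alone.

In a functional assay on cells (Cancer cell lines, Homo sapiens) for inhibition (a higher number here means a weaker inhibitor of growth, a lower number a stronger inhibitor of growth), compound 1 `COc1ccc(-c2nc3sc(Cc4ccccc4)nn3c2SC#N)cc1` gives 4800 nM; compound 2 `O=Cc1c(-c2ccc([N+](=O)[O-])cc2)nc2sc(Cc3ccccc3)nn12` gives 2800 nM; compound 3 `O=[N+]([O-])c1ccc(-c2nc3sc(Cc4ccccc4)nn3c2Br)cc1` gives 17400 nM.

Compound 2 has the lowest number of the three, but compound 1 lies within the scatter of it, so no order between those two is claimed; only compound 3 stands clearly apart. Compound 4 `O=Cc1c(-c2ccc(Br)cc2)nc2sc(Cc3ccccc3)nn12` differs from compound 2 by bromo in place of nitro on an aromatic carbon. Within the data shown here, the one measured step, a 6.2-fold higher number from compound 2 to compound 3 (0.79 log units; beyond the scatter), alters a different place on the shared core and does not bear on this swap; no measured pair exchanges the nitro. Among the measured compounds shown here, with no step to lean on, compound 4 is expected to stay near compound 2, a 1.3-fold higher number from compound 2 to compound 4 (0.10 log units; within the scatter), nothing beyond the scatter. Compound 4 is estimated at 3500 nM, with a range from 1200 nM to 10000 nM.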

Compound 4, concentration for 50% growth inhibition: 3500 nM
Compound 4: the middle estimate sits on the measured number at the digits printed, and the stated range covers the measured number.
By their numbers in this assay, from the lowest: compounds 2, 4 and 1 (each within the scatter of the next); then compound 3.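

In this assay, the exchange of nitro for bromo on an aromatic carbon, para to a large group, gives a 1.3-fold higher number from compound 2 to compound 4 (0.10 log units; within the scatter), so the number of compound 2 does not depend on nitro at this position while formyl stays in place. The earlier compounds had shown a step only at the other place, where bromo replaces formyl. No measurement offered here accounts for the two groups reading alike. Still open, on these data alone, is whether an amine or a carboxylic acid at this position would also stay within the scatter of compound 2.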